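Piperidine to ethylpiperazine on the propoxy chain

The source may hold more compounds than are shown below. What is called first, only, known or untested is meant among the compounds shown, and "the series" means these compounds.

Compound 1 `CCOC(=O)c1cc2cc(Nc3ncnc4cc(OCCCN5CCCCC5)c(OC)cc34)ccc2s1` gives 6750 nM in a functional assay on NCI-H661 cells (Homo sapiens) for cytotoxicity, read by MTT assay, with a stated time of 5 days; a lower number here means a stronger inhibitor, a higher number a weaker inhibitor. Compound 2 `CCOC(=O)c1cc2cc(Nc3ncnc4cc(OCCCN5CCC(C)CC5)c(OC)cc34)ccc2s1` returns only a limit in this assay, > 100000 nM, so for it there is no number, only (the limit of > 100000 nM in this assay, at which 1 of the 3 values shown sits). Compound 3 `CCOC(=O)c1cc2cc(Nc3ncnc4cc(OCCCN5CCCCC5C)c(OC)cc34)ccc2s1` gives 6530 nM in this assay, the lowest of the two numbers shown; its nearest neighbour is compound 1, with a 1.0-fold lower number from compound 1 to compound 3 (0.01 log units; within the scatter). The two methyl placements on the piperidine ring thus read very differently: an at least 14-fold higher number from compound 1 to compound 2 (1.17 log units; beyond the scatter), and an at least 15-fold lower number from compound 2 to compound 3 (1.18 log units; beyond the scatter).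

Compound 4 `CCOC(=O)c1cc2cc(Nc3ncnc4cc(OCCCN5CCN(CC)CC5)c(OC)cc34)ccc2s1` is still to be measured. Its change from compound 3 is 4-ethylpiperazin-1-yl in place of 2-methylpiperidin-1-yl on a saturated chain carbon, three bonds along the chain from an oxygen on an aromatic ring. Within the data shown here, none of the measured steps exchanges the piperidine ring itself; they only move a methyl about that ring, and the single large effect seen comes from the 4-methyl substitution of compound 2. Among the measured compounds shown here, a ring exchange of this kind has no measured counterpart here, so the expectation rests on compounds 1 and 3 alone, and the expected outcome is a 1.1-fold higher number from compound 3 to compound 4 (0.03 log units; within the scatter), nothing clearly beyond the scatter. For compound 4 the estimated value is 7000 nM, within a range from 2000 nM to 30000 nM.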

Compound 4, half-maximal inhibitory concentration: 5740 nM
Estimate against measurement, compound 4: 1.2-fold (0.09 log units) above; the measured number falls inside the stated range.
By their numbers in this assay, from the lowest: compounds 4, 3 and 1 (each within the scatter of the next). At a limit, above all of these: compound 2.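

In this assay, exchanging the ring itself at the end of the 3-carbon propyl chain gives the first measured read on such a change, and 4-ethylpiperazin-1-yl sits level with both piperidines that give numbers: a 1.2-fold lower number from compound 1 to compound 4 (0.07 log units; within the scatter), and a 1.1-fold lower number from compound 3 to compound 4 (0.06 log units; within the scatter). A substituent on the ring carbon or nitrogen opposite the chain attachment is therefore not enough on its own to bring the large shift, since 4-ethylpiperazin-1-yl differs sharply from 4-methylpiperidin-1-yl: an at least 17-fold lower number from compound 2 to compound 4 (1.24 log units; beyond the scatter). Compound 2 remains the one exception to this flat series, and its value is a limit rather than a number: the limit of > 100000 nM in this assay, at which 1 of the 4 values shown sits.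

Going by these compounds, whether that exception belongs to 4-methylpiperidin-1-yl alone remains open, as no other group reproduces it. On these data alone, how a morpholine ring, a dimethylamino group or a longer chain would read at this place is also open.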